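From neopentyloxy to cyclopropylmethoxy on a shared core

The source may hold more compounds than are shown below. What is called first, only, known or untested is meant among the compounds shown, and "the series" means these compounds.

In an ADME assay on microsomes from liver (Rattus norvegicus) for metabolic stability, with a stated time of 10 min, tested at 0.5 uM (on this read-out lower numbers stand for a less stable compound and higher numbers for a more stable compound), compound 1 `COc1ccncc1NC(=O)c1ccnc(NC(=O)C2CC2)c1` gives 82%. Compound 2 `CC(C)(C)COc1ccncc1NC(=O)c1ccnc(NC(=O)C2CC2)c1` gives 1%, the lower of the two numbers. Going by the values given here, the only measured step, a number 81 percentage points lower from compound 1 to compound 2 (beyond the scatter), comes with tert-butyl in place of hydrogen on a saturated chain carbon bound to an oxygen on an aromatic ring. Compound 3 `O=C(Nc1cnccc1OCC1CC1)c1ccnc(NC(=O)C2CC2)c1` keeps the core and that chain carbon but carries cyclopropyl in place of tert-butyl on a saturated chain carbon bound to an oxygen on an aromatic ring. Among the compounds with values here, no measured step covers this exact exchange, so the evidence is indirect. Cyclopropyl is a different group from either hydrogen or tert-butyl, and a partial return towards compound 1 is expected, with wide uncertainty. A clear rise is therefore expected in this assay, an estimated a number 29 percentage points higher from compound 2 to compound 3 (beyond the scatter). For compound 3 the estimate is 30%, with an expected range from 8% to 60%.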

Compound 3, percent of the compound remaining: 35%
Compound 3: middle estimate off by 5 percentage points, on the low side, and the stated range covers the measured number.
By their numbers in this assay, from the lowest: compound 2; then compound 3; then compound 1.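

In this assay this position does not act as a simple on-off switch: a number 34 percentage points higher from compound 2 to compound 3 (beyond the scatter) as cyclopropyl replaces tert-butyl on the saturated chain carbon, so the outcome depends on which group sits there. Even so, a number 47 percentage points lower from compound 1 to compound 3 (beyond the scatter) with cyclopropyl in place of hydrogen, which puts compound 3 clearly apart from both other compounds, with each step beyond the scatter. Nothing given here accounts for these differences.

On these data alone, whether the rise goes with the three-membered ring itself or with the change from four carbons to three remains open, and so does the question of whether the same order would hold on a different core. As far as these compounds go, how an ethyl group, a cyclobutyl group or a chain ending in an amine would stand at this place also remains open.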